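Chloro Replaced by Benzyloxy on a Shared Thiazole-Free Core

This account rests on a few compounds, and the source may have more. Where it says the series, first, only, none or still open, it means among the compounds named here.

Compound 1 `CCOCCOC(=O)C(=O)Nc1nc(-c2cc(Cl)no2)cs1` was tested in a functional assay on the whole organism with Rattus norvegicus as the target; on this read-out lower numbers stand for an effect already at smaller amounts and higher numbers for an effect only at larger amounts of compound. In this assay compound 1 gives only a limit, > 30 mg/kg, not a number. Compound 2 `CCOC(=O)C(=O)Nc1nc(-c2cc(Br)no2)cs1` likewise gives only a limit in this assay, > 100 mg/kg. Both values shown sit at limits, the limit of > 30 mg/kg in this assay, at which 1 of the 2 values shown sits, and (the limit of > 100 mg/kg in this assay, at which 1 of the 2 values shown sits), so compound 1 cannot be placed against compound 2.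

Compound 3 `CCOCCOC(=O)C(=O)Nc1nc(-c2cc(OCc3ccccc3)no2)cs1` differs from compound 1 by benzyloxy in place of chloro on an aromatic carbon. Among the measured compounds shown here, no step between measured compounds is known, so nothing anchors the size of this change. Compound 3 is expected near the limit, at an estimated 50 mg/kg with a range from 20 mg/kg to 300 mg/kg. The step that the limit leaves unreadable from compound 1 to compound 3 is expected to stay within the scatter.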

Compound 3, dose for half-maximal effect: > 100 mg/kg
Compound 3 gave a limit, no number; the forecaster's own chance of this, stated with the estimate: 70%; middle value at least 2.0-fold (0.30 log units) away from the limit.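

In this assay, among the compounds shown here, compound 1 and compound 3 both give only limits, not numbers, so no step between them can be read. The compounds shown leave open whether benzyloxy in place of chloro changes the dose needed for an effect.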